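Methoxyphenyl isomers on an aromatic nitrogen

A few compounds are considered here, and "the series" means these few. Any claim that something is new, unique, unknown or untested is made for them only; others in the source may bear on it.

In an ADME assay on microsomes from liver (Mus musculus) for metabolic stability, read by LC-MS, tested at 1 uM (on this read-out lower numbers stand for slow clearance and higher numbers for fast clearance), compound 1 `CCOC(=O)C1=C(C)N/C(=C/c2cc(C)n(-c3ccc(CN(C)C)cc3)c2C)C1=O` gives 31 mL.min-1.g-1 and compound 2 `CCOC(=O)C1=C(C)N/C(=C/c2cc(C)n(-c3ccc(OC)cc3)c2C)C1=O` gives 54 mL.min-1.g-1. Within the data shown here, these two values lie within the scatter of each other, and compound 2 stands apart from no other measured compound. Compound 3 `CCOC(=O)C1=C(C)N/C(=C/c2cc(C)n(-c3cccc(OC)c3)c2C)C1=O` differs from compound 2 by 3-methoxyphenyl in place of 4-methoxyphenyl on an aromatic nitrogen. Among the measured compounds shown here, the one measured step, a 1.7-fold higher number from compound 1 to compound 2 (0.24 log units; within the scatter), exchanges a different group and stays within the scatter, so it is only a weak guide. For the measured compounds named here, no measured step moves a methoxy group. A step beyond the scatter in this assay is therefore not expected, and no direction is favoured. The expected step is a 1.1-fold lower number from compound 2 to compound 3 (0.03 log units; within the scatter). For compound 3 the estimated value is 50 mL.min-1.g-1, with an expected range of 25 mL.min-1.g-1 to 100 mL.min-1.g-1.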

Compound 3, intrinsic clearance in microsomes: 150 mL.min-1.g-1
For compound 3 the middle estimate is 3.0-fold (0.48 log units) below the measured one; measured number outside the range, above it.
By their numbers in this assay, from the lowest: compounds 1 and 2 (each within the scatter of the next); then compound 3.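

In this assay the read-out on the aromatic nitrogen depends on where the methoxy group sits: 3-methoxyphenyl in place of 4-methoxyphenyl gives a 2.8-fold higher number from compound 2 to compound 3 (0.44 log units; beyond the scatter) with the same atoms joined differently. 3-Methoxyphenyl in place of 4-((dimethylamino)methyl)phenyl gives a 4.8-fold higher number from compound 1 to compound 3 (0.68 log units; beyond the scatter) and so, like the isomer swap, goes beyond the scatter, which the earlier step did not. No measurement at hand explains this difference.

Open, on these data alone, is whether the same shift holds for other groups on the phenyl ring, such as a carboxylic acid or a primary amine in place of methoxy.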